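Methoxy in place of methyl: expectation for compound 4

This account rests on a few compounds, and the source may have more. Where it says the series, first, only, none or still open, it means among the compounds named here.

Compound 1 `Cc1ccc2nc(C(=O)Nc3c(F)cc(-c4cccc(F)c4)cc3F)c(C)c(O)c2c1` gives 56.4% in a functional assay on A-375 cells (Homo sapiens) for antiproliferative activity, read by MTT assay, with a stated time of 24 h, tested at 100 ug/mL; on this read-out lower numbers stand for a weaker effect and higher numbers for a stronger effect at the one concentration tested.
Compound 2 `CCOc1ccc2nc(C(=O)Nc3c(F)cc(-c4cccc(F)c4)cc3F)c(C)c(O)c2c1` gives 37.9% in this assay.
Compound 3 `Cc1ccc2nc(C(=O)Nc3c(F)cc(-c4cccc(F)c4)cc3F)c(C)c(C(=O)O)c2c1` gives 37.3% in this assay.

Compound 3 has the lowest of the three numbers. Compound 2 is within the scatter of it, so the two cannot be set in order. Compound 1 lies beyond the scatter above it: a number 19.1 percentage points lower from compound 1 to compound 3 (beyond the scatter).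

Compound 4 `COc1ccc2nc(C(=O)Nc3c(F)cc(-c4cccc(F)c4)cc3F)c(C)c(C(=O)O)c2c1` is not yet measured. It differs from compound 3 by methoxy in place of methyl on an aromatic carbon. Going by the values given here, the only measured step that bears on this is the one in the same part of the core, a number 18.5 percentage points lower from compound 1 to compound 2 (beyond the scatter), where an alkoxy group also enters in place of methyl. That step was modest and downward; a smaller alkoxy group is a less drastic change, and compound 3 already stands low, so a downward step of similar or somewhat smaller size is expected in this assay. Compound 4 is therefore estimated at 27%, with a range of 12% to 42%. The expected step is a number 10.3 percentage points lower from compound 3 to compound 4 (beyond the scatter); a result within the scatter of compound 3 would not be surprising.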

Compound 4, a percentage reported as inhibition, at one concentration (the size of the read-out at that concentration, not a potency): 58.7%
The estimate for compound 4 lay 31.7 percentage points below the measured number; measured number above the stated range.
By their numbers in this assay, from the lowest: compounds 3 and 2 (each within the scatter of the next); then compounds 1 and 4 (each within the scatter of the next).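

In this assay, methoxy in place of methyl on this aromatic carbon gives a number 21.4 percentage points higher from compound 3 to compound 4 (beyond the scatter), so an alkoxy group here does not lower the number in every setting, as a number 18.5 percentage points lower from compound 1 to compound 2 (beyond the scatter) alone had suggested. The two steps run in opposite directions, the downward one with ethoxy in the hydroxy compounds and the upward one with methoxy in the carboxy compounds, so the outcome of replacing methyl at this place is not fixed by the change alone. Nothing available explains the upward step.

As far as these compounds go, each alkoxy group appears here with only one of the hydroxy and carboxy groups, so it remains open which of the two differences sets the direction. From the compounds shown here alone, how a propoxy chain or an amine on this carbon would read also remains open.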